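This account rests on a few compounds, and the source may have more. Where it says the series, first, only, none or still open, it means among the compounds named here.

Working notes on the series. Compound 1 `O=C1CSC(c2ccccc2Cl)N1c1nnc(S)s1` and compound 2 `O=C1CSC(c2ccccc2)N1c1nnc(S)s1` share one core; compound 3 `CS(=O)(=O)c1ccc(NC(=O)CSc2nnc(N3C(=O)CSC3c3ccccc3Cl)s2)cc1` and compound 4 `CS(=O)(=O)c1ccc(NC(=O)CSc2nnc(N3C(=O)CSC3c3ccccc3)s2)cc1` share another, and the difference between the two cores is not broken down here. In an ADME assay on MT4 cells (Homo sapiens) for cytotoxicity, read by MTT assay, with a stated time of 5 days (a higher number here means that more compound is tolerated, a lower number that less compound is tolerated), compound 1 gives 200000 nM. Compound 2 reaches only a limit of the assay, > 423000 nM. The change hydrogen in place of chloro on an aromatic carbon therefore gives an at least 2.1-fold higher number from compound 1 to compound 2 (0.32 log units; beyond the scatter), and the step is open-ended because of the limit of > 423000 nM in this assay, at which 1 of the 3 values shown sits. Compound 3 likewise shows only a limit in this assay, >= 172000 nM. Its position is fixed only by the limit of >= 172000 nM in this assay, at which 1 of the 3 values shown sits. The change hydrogen in place of chloro on an aromatic carbon is the same change as in the first pair, at a place described in the same words. With compound 3 already at a limit and the measured pair showing an at least 2.1-fold higher number from compound 1 to compound 2 (0.32 log units; beyond the scatter), the step in this assay is expected to be no smaller than the earlier one, a step that the limit leaves unreadable from compound 3 to compound 4. Compound 4 is accordingly estimated at 320000 nM, between 170000 nM and 600000 nM, and is expected most likely to be reported as a limit rather than a number.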

Compound 4, half-maximal cytotoxic concentration: 131000 nM
Compound 4: the middle estimate sits 2.4-fold (0.39 log units) above what was measured, outside the stated range (below it).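

In this assay, the change 2-chlorophenyl to phenyl on the core of compound 3 gives an at least 1.3-fold lower number from compound 3 to compound 4 (0.11 log units; that floor lies within the scatter). The change therefore does not carry over unchanged from one core to the other, and the two steps differ in direction: the same change on two cores in this assay, an at least 2.1-fold higher number (0.32 log units; beyond the scatter) from compound 1 to compound 2 and an at least 1.3-fold lower number (0.11 log units; that floor lies within the scatter) from compound 3 to compound 4, at least 2.7-fold (0.44 log units) apart, beyond the scatter of two such steps Each pair holds a limit of the assay, compound 2 on one core and compound 3 on the other, so the true size of either step stays unread, and nothing here tells why the two steps differ.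

Open, going by these compounds, is whether fluoro, methoxy or an amine at the same place on the six-membered aromatic ring would follow the pattern of the core of compound 1 or that of the core of compound 3 in this assay. Also open, on these data alone, is how the change reads on further cores, for instance with a carboxylic acid or a longer chain on the sulfur of the core of compound 1.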